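The source may hold more compounds than are shown below. What is called first, only, known or untested is meant among the compounds shown, and "the series" means these compounds.

Among the compounds with values here, in a functional assay on SK-BR-3 cells (Homo sapiens) for antiproliferative activity (on this read-out lower numbers stand for stronger inhibition and higher numbers for weaker inhibition), compound 2 `COc1cccc(Oc2ccc3cc(NC(=O)c4ccc(O)c(CC=C(C)C)c4)c(=O)oc3c2C)c1` gives 33100 nM, the higher of the two plain numbers measured so far. Within the data shown here, its nearest neighbour, compound 1 `COc1cccc(Oc2ccc3cc(NC(=O)c4ccc(OC(C)=O)c(CC=C(C)C)c4)c(=O)oc3c2C)c1`, gives 13700 nM; the only measured step, a 2.4-fold higher number from compound 1 to compound 2 (0.38 log units; beyond the scatter), is a modest one. Compound 3 `COc1cccc(-c2cc(C(=O)Nc3cc4ccc(Oc5ccc(C(C)(C)C)cc5)c(C)c4oc3=O)ccc2OC)c1` gives > 100000 nM, which is the limit of > 100000 nM in this assay, at which 1 of the 3 values shown sits.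

Compound 4 `COc1cccc(Cc2ccc3cc(NC(=O)c4ccc(O)c(CC=C(C)C)c4)c(=O)oc3c2C)c1` carries 3-methoxybenzyl in place of 3-methoxyphenoxy on an aromatic carbon. Among the measured compounds shown here, the one measured step concerns a different part of the shared core, so it says little about this change, and no other step touches it. The expected step is therefore none beyond the scatter, with the uncertainty wide in both directions. The estimate for compound 4 in this assay is 35000 nM, within 10000 nM to 100000 nM, meaning an expected step of a 1.1-fold higher number from compound 2 to compound 4 (0.02 log units; within the scatter).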

Compound 4, half-maximal inhibitory concentration: 14800 nM
Compound 4: the middle estimate sits 2.4-fold (0.37 log units) above what was measured, within the range that was stated.
By their numbers in this assay, from the lowest: compounds 1 and 4 (each within the scatter of the next); then compound 2. At a limit, above all of these: compound 3.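

The first read at this position comes from replacing 3-methoxyphenoxy with 3-methoxybenzyl on the aromatic carbon, which gives a 2.2-fold lower number from compound 2 to compound 4 (0.35 log units; beyond the scatter) in this assay. The change is modest but beyond the scatter, so the group at this position does affect the read-out, and the oxygen link of compound 2 is not needed to keep this level of activity. Nothing measured on these compounds explains the step.

As far as these compounds go, whether an amine link at this position, or a longer chain carrying the same 3-methoxyphenyl ring, would lower the number further stays open. Also open, from the compounds shown here alone, is whether the acetyl on oxygen, as carried by compound 1, would shift the number on the 3-methoxybenzyl compound as well.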